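This account rests on a few compounds, and the source may have more. Where it says the series, first, only, none or still open, it means among the compounds named here.

Measured in an assay on isolated protein with Bile acid receptor (Homo sapiens) as the target; on this read-out higher numbers stand for an effect only at larger amounts of compound and lower numbers for an effect already at smaller amounts:
compound 1 `COC(=O)/C=C/c1cccc(N(Cc2ccc(/C=C/c3cccc(F)c3)cc2)C(=O)C2CCCCC2)c1` gives 86 nM;
compound 2 `COC(=O)/C=C/c1cccc(N(Cc2ccc(/C=C/c3cccc(F)c3)cc2)C(=O)C(C)C)c1` gives 71 nM;
compound 3 `COC(=O)/C=C/c1cccc(N(Cc2ccc(-c3cccc(OC)c3)cc2)C(=O)NC(C)C)c1` gives 1370 nM.

Compound 2 shows the lowest number of the three, though it sits within the scatter of compound 1 (a 1.2-fold lower number from compound 1 to compound 2 (0.08 log units; within the scatter)), while compound 3 lies well above it. Compound 4 `COC(=O)/C=C/c1cccc(N(Cc2ccc(-c3cccc(C)c3)cc2)C(=O)C(C)C)c1` differs from compound 2 by 3-methylphenyl in place of 2-(3-fluorophenyl)ethenyl on an aromatic carbon. Among the compounds with values here, no measured step covers this change: the only single-point step, from compound 1 to compound 2, concerns the group on the carbonyl carbon and was within the scatter. Compound 3 carries a different aromatic group at the same place but also a different group on the carbonyl, so its higher number cannot be assigned to either change alone. A moderate rise is therefore expected for compound 4, a 4.2-fold higher number from compound 2 to compound 4 (0.63 log units; beyond the scatter), giving an estimate of 300 nM with a range of 80 nM to 1200 nM.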

Compound 4, half-maximal effective concentration: 163 nM
Estimate against measurement, compound 4: 1.8-fold (0.26 log units) above; the range from low to high includes it.
By their numbers in this assay, from the lowest: compounds 2, 1 and 4 (each within the scatter of the next, the first and the last beyond it); then compound 3.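

With the isopropyl carbonyl held fixed, the aromatic group para to a large group can now be read on its own in this assay: a 2.3-fold higher number from compound 2 to compound 4 (0.36 log units; beyond the scatter). Exchanging 2-(3-fluorophenyl)ethenyl for the smaller 3-methylphenyl therefore costs only a modest step, although the loss of the double bond and fluorine and the gain of methyl cannot be separated. Nothing available explains this step.

Still open, as far as these compounds go, is how 3-fluorophenyl, with no ethenyl link, would read at this place. Also open, from the compounds shown here alone, is the effect of an amine or a carboxylic acid on that outer ring.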